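A Methoxy Added to Compound 2: What to Expect

The source may report more compounds than this note shows. Statements on the series, on what has been measured and on what is new or still open speak of the compounds shown alone.

Compound 1 `FC(F)(F)c1ccc(CSc2nc(Nc3cccc(C(F)(F)F)c3)c3ccccc3n2)cc1` carries a 3-(trifluoromethyl)phenyl on the nitrogen of the shared core. In a functional assay on MDA-MB-231 cells (Homo sapiens) for cytotoxicity, read by MTT assay, with a stated time of 72 h (on this read-out lower numbers stand for stronger inhibition and higher numbers for weaker inhibition), compound 1 gives 11100 nM. Compound 2 `COc1cc(Nc2nc(SCc3ccc(C(F)(F)F)cc3)nc3ccccc23)cc(OC)c1` keeps the rest and places a 3,5-dimethoxyphenyl on that nitrogen instead; in this assay compound 2 gives 16100 nM. Among the compounds with values here, the step of a 1.5-fold higher number from compound 1 to compound 2 (0.16 log units; within the scatter) is the only comparison in hand. Of the two measured numbers compound 2 has the highest, and its nearest neighbour, compound 1, lies within the scatter of it, so the two cannot be told apart.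

Compound 3 `COc1cc(Nc2nc(SCc3ccc(C(F)(F)F)cc3)nc3ccccc23)cc(OC)c1OC` differs from compound 2 in one place: methoxy in place of hydrogen on an aromatic carbon. Within the data shown here, the one measured step touching this part of the molecule, from compound 1 to compound 2, exchanged the whole aryl group on the nitrogen and still stayed within the scatter. Adding a single methoxy to that same aryl is a smaller alteration, and no measured step points in either direction. Compound 3 is therefore expected to show a step of a 1.0-fold lower number from compound 2 to compound 3 (0.00 log units; within the scatter) in this assay, none beyond the scatter. The estimate for compound 3 is 16000 nM, with a range from 6000 nM to 40000 nM.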

Compound 3, half-maximal inhibitory concentration: > 50000 nM
Compound 3: only a limit was reported; the forecaster's own chance of this, stated with the estimate: 10%; at least 3.1-fold (0.49 log units) between middle value and limit.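

Placing a methoxy on the aromatic carbon ortho to two methoxy groups and para to a large group gives an at least 3.1-fold higher number from compound 2 to compound 3 (0.49 log units; beyond the scatter) in this assay. Within the data shown here, the earlier exchange of the whole aryl group on the nitrogen gave only a 1.5-fold higher number from compound 1 to compound 2 (0.16 log units; within the scatter), so this position, on the 3,5-dimethoxyphenyl of compound 2, is the first place in these compounds where a change moves the number beyond the scatter, and a change of just one methoxy is enough to do so. The reading for compound 3 is a limit and not a number, so the step fixes only a lower bound on the change, and how far the true number lies past that limit stays unknown: the limit of > 50000 nM in this assay, at which 1 of the 3 values shown sits.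

Whether a hydroxyl, an amine, a fluorine atom or an ethoxy at this place would raise the number as the methoxy does remains open, so the compounds shown do not separate a result specific to methoxy from one that any group here would give. Also open, from the compounds shown here alone, is whether a methoxy at this place would do the same with the two other methoxy groups replaced by hydrogen.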